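Series notes: the aromatic nitrogen substituent of compound 1

A few compounds are considered here, and "the series" means these few. Any claim that something is new, unique, unknown or untested is made for them only; others in the source may bear on it.

The series shares the core of compound 1 `CC(C)(C)OC(=O)N1CCN(C(=S)SCc2cn(-c3ccccc3F)nn2)CC1`. In a functional assay on PC-3 cells (Homo sapiens) for inhibition, read by MTT assay, with a stated time of 72 h (on this read-out higher numbers stand for weaker inhibition and lower numbers for stronger inhibition), compound 1 reports only a limit of the assay, > 128000 nM. Compound 2 `S=C(SCc1cn(Cc2ccc(Cl)c(Cl)c2)nn1)N1CCNCC1` carries the same core with a different group on the aromatic nitrogen; in this assay compound 2 has no result recorded, "not determined" (no result reported). Compound 3 `O=C(OCc1ccccc1)N1CCN(C(=S)SCc2cn(Cc3ccc(Cl)c(Cl)c3)nn2)CC1` reports in this assay only a limit, > 128000 nM. For the measured compounds named here, compound 1 therefore stands at the limit of the assay, as does compound 3, which is summarised by the limit of > 128000 nM in this assay, at which 2 of the 3 values shown sit; no single number and no measured step between compounds is available in this assay.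

Compound 4 `CC(C)(C)OC(=O)N1CCN(C(=S)SCc2cn(Cc3ccc(Cl)cc3)nn2)CC1` differs from compound 1 in one place: 4-chlorobenzyl in place of 2-fluorophenyl on an aromatic nitrogen. Going by the values given here, no step between measured compounds exists to calibrate this change. With compound 1 at the limit and compound 3 at the same limit, no movement beyond the scatter is expected. The expected step is a number no higher from compound 1 to compound 4 (the limit leaves the size open). Compound 4 is estimated to give about 128000 nM in this assay, within 40000 nM to 300000 nM, and most likely to be reported again only as a limit.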

Compound 4, half-maximal inhibitory concentration: > 128000 nM
Compound 4 was reported as a limit; the forecaster's own chance of this, stated with the estimate: 75%; the middle value sits exactly at the limit.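

In this assay compound 1 and compound 4 both stand only as limits of the assay, and no step can be read between them. The compounds shown leave open whether any group on the aromatic nitrogen of the shared core gives a single measured number rather than a limit in this assay as a read-out.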